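Trimming a hydroxymethyl from an alkynyl thioether

The source may report more compounds than this note shows. Statements on the series, on what has been measured and on what is new or still open speak of the compounds shown alone.

Measured compounds:
compound 1, `OCC#CCSc1cnc2ccccc2c1SCC#CCCl`: 43.4 ug/mL
compound 2, `CSc1cnc2ccccc2c1SCC#CCO`: 49.8 ug/mL
compound 3, `ClCC#CCSc1cnc2ccccc2c1Cl`: 4 ug/mL

In a functional assay on B16 cells (Mus musculus) for antiproliferative activity, with a stated time of 72 h (on this read-out lower numbers stand for stronger inhibition and higher numbers for weaker inhibition), compound 1 gives 43.4 ug/mL. Among the three numbers it stands second highest. Its nearest neighbour is compound 2, whose number lies within the usual scatter of it, so no order between these two can be read. The furthest is compound 3, whose much lower number lies beyond the scatter. Among the measured compounds shown here, no two of the measured compounds differ in only one place, so the measured set offers no single step to lean on.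

Compound 4, `C#CCSc1cnc2ccccc2c1SCC#CCCl`, is compound 1 with one change: hydrogen in place of hydroxymethyl on a triple-bonded carbon. The second thioether chain on the shared core is kept unchanged.

For the measured compounds named here, with no measured example of this change, the expectation is cautious: in this assay the step is expected to be small, within the scatter or at most a modest lowering of the number. The estimated step is a 1.2-fold lower number from compound 1 to compound 4 (0.09 log units; within the scatter). Compound 4 is therefore expected to give about 35 ug/mL, within a range from 12 ug/mL to 100 ug/mL.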

Compound 4, concentration for 50% inhibition: 52.8 ug/mL
The estimate for compound 4 lay 1.5-fold (0.18 log units) below the measured number; low and high end bracket the measured number.
By their numbers in this assay, from the lowest: compound 3; then compounds 1, 2 and 4 (each within the scatter of the next).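

In this assay, hydrogen in place of hydroxymethyl on a triple-bonded carbon gives a 1.2-fold higher number from compound 1 to compound 4 (0.09 log units; within the scatter) and this first single-place step shows that the read-out does not separate the 4-hydroxybut-2-yn-1-yl chain from the propargyl chain on this core. With the second thioether chain kept unchanged, the hydroxymethyl therefore makes no difference that can be read in this assay. Nothing available on these compounds speaks to why the two numbers lie so close.

What the compounds shown leave open is whether an aminomethyl group, a carboxylic acid or a longer alkyl chain on this triple-bonded carbon would move the number beyond the scatter. Also open, from the compounds shown here alone, is whether hydroxymethyl and hydrogen would stay as close with a different second chain on the shared core.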